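The source may report more compounds than this note shows. Statements on the series, on what has been measured and on what is new or still open speak of the compounds shown alone.

Working notes on the series, three measured entries and one open entry. Compound 1 `O=C1/C(=C\c2cccc(Oc3ccccc3)c2)c2ccccc2N1c1c(Cl)cccc1Cl` is the phenoxy-bearing member; in a functional assay on HuTu80 cells (Homo sapiens) for cytotoxicity, read by MTT assay, with a stated time of 72 h (on this read-out lower numbers stand for an effect already at smaller amounts and higher numbers for an effect only at larger amounts of compound), compound 1 gives 10 ug/mL. Compound 2 `O=C1/C(=C\c2cccc(Br)c2)c2ccccc2N1c1c(Cl)cccc1Cl` carries a bromo group in place of the phenoxy group; in this assay compound 2 gives 7 ug/mL. Compound 3 `Cc1ccc2nc(Cl)c(/C=C3\C(=O)N(c4c(Cl)cccc4Cl)c4ccccc43)cc2c1` belongs to the set, but in this assay compound 3 gives "not determined" (no result reported), so no number is available for it. On the two numbers available, compound 2 holds the lower one, but the gap to compound 1 does not exceed the scatter, so no order between the two can be claimed.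

The open entry is compound 4 `O=C1/C(=C\c2ccc(Cl)cc2)c2ccccc2N1c1c(Cl)cccc1Cl`. Relative to compound 2 the change is 4-chlorophenyl in place of 3-bromophenyl on a double-bonded chain carbon bound to a double-bonded ring carbon.

For the measured compounds named here, the single step that has been measured, a 1.4-fold lower number from compound 1 to compound 2 (0.15 log units; within the scatter), exchanged one group on the same aromatic ring and stayed inside the scatter. Going by the values given here, it is the only step that bears on an exchange of this kind, and it gives no sign that a change on this ring moves the read-out. No step beyond the scatter is therefore expected in this assay for compound 4, and the expected shift a 1.1-fold higher number from compound 2 to compound 4 (0.06 log units; within the scatter) is accordingly small.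

The estimate for compound 4 in this assay is 8 ug/mL, with a range from 4 ug/mL to 16 ug/mL.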

Compound 4, concentration for half-maximal effect: 6 ug/mL
Compound 4: middle estimate off by 1.3-fold (0.12 log units), on the high side; measured number inside the range.
By their numbers in this assay, from the lowest: compounds 4, 2 and 1 (each within the scatter of the next).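

Exchanging 3-bromophenyl for 4-chlorophenyl on a double-bonded chain carbon bound to a double-bonded ring carbon gives a 1.2-fold lower number from compound 2 to compound 4 (0.07 log units; within the scatter) in this assay. Unlike the earlier phenoxy-to-bromo step, this exchange alters both the halogen and the printed ring location of the substituent, and the read-out still stays within the scatter, so the series now holds a second step at this place with no readable difference. No measurement shown offers an explanation for this result, and none bears on how either group acts in the cells.

Compound 2 and compound 4 differ in the halogen and in its location on the phenyl ring at once, so the pair cannot show what either change does alone, and a small difference from one could be offset by the other. From the compounds shown here alone, whether an amine or a carboxylic acid in place of the halogen on this phenyl ring would also stay within the scatter in this assay remains open, as the compounds with numbers carry only bromo, chloro and phenoxy groups there.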